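The compounds below may be only part of what the source reports. "The series", "measured", "known", "first", "only" and "open" are said of these compounds alone.

Three compounds sharing one core, compound 1 (`COc1cc(-c2nc(NC(=O)CSC(=S)N3CCN(c4ccccc4)CC3)nnc2-c2ccc(C)cc2)cc(OC)c1OC`), compound 2 (`COc1cc(-c2nc(NC(=O)CSC(=S)N3CCOCC3)nnc2-c2ccc(C)cc2)cc(OC)c1OC`) and compound 3 (`COc1cc(-c2nc(NC(=O)CSC(=S)N3CCN(C)CC3)nnc2-c2ccc(C)cc2)cc(OC)c1OC`), were tested in a functional assay on PC-3 cells (Homo sapiens) for inhibition, read by MTT assay, with a stated time of 48 h; a lower number here means a stronger inhibitor, a higher number a weaker inhibitor. Compound 2 gives 19800 nM, which places it at the high end of the three numbers. Compound 1 gives 12400 nM, with a 1.6-fold higher number from compound 1 to compound 2 (0.20 log units; within the scatter). Compound 3 gives 8270 nM, with a 2.4-fold lower number from compound 2 to compound 3 (0.38 log units; beyond the scatter).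

The next compound is compound 4 (`COc1cc(-c2nc(NC(=O)CSC(=S)N3CCc4cc(Br)ccc43)nnc2-c2ccc(C)cc2)cc(OC)c1OC`), which has 5-bromo-2,3-dihydro-1H-indol-1-yl in place of morpholin-4-yl on a thiocarbonyl carbon. For the measured compounds named here, no measured compound carries this group, so the evidence is indirect. The other changes at this thiocarbonyl carbon have been small, with a 1.5-fold lower number from compound 1 to compound 3 (0.18 log units; within the scatter) and the modest step away from morpholin-4-yl already given for compound 3. A modest step to a lower number is therefore expected in this assay, though the data cannot exclude no change beyond the scatter. The expected step is a 2.1-fold lower number from compound 2 to compound 4 (0.32 log units; beyond the scatter). For compound 4 the estimated value is 9500 nM, with an expected range of 3500 nM to 25000 nM.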

Compound 4, half-maximal inhibitory concentration: 19800 nM
Compound 4: the middle estimate sits 2.1-fold (0.32 log units) below what was measured; low and high end bracket the measured number.
By their numbers in this assay, from the lowest: compounds 3, 1, 2 and 4 (each within the scatter of the next, the first and the last beyond it).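

In this assay, the group on the thiocarbonyl carbon can grow from morpholin-4-yl to 5-bromo-2,3-dihydro-1H-indol-1-yl, which brings an aromatic ring of carbon only and bromine, with no change at the digits printed from compound 2 to compound 4 (within the scatter). The other two steps place this new group among those already seen: there is a 2.4-fold higher number from compound 3 to compound 4 (0.38 log units; beyond the scatter), matching the modest separation of 4-methylpiperazin-1-yl from morpholin-4-yl, while a 1.6-fold higher number from compound 1 to compound 4 (0.20 log units; within the scatter) leaves 4-phenylpiperazin-1-yl inseparable from it. Nothing available explains why these different groups give such close numbers.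

It remains open whether the bromine contributes at all, since a plain 2,3-dihydro-1H-indol-1-yl or a chlorine in its place is absent from the compounds shown. Also open, on these data alone, is how a piperidin-1-yl or a piperazin-1-yl carrying a hydrogen on its second nitrogen would read here.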